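Swapping Benzyl for Cyclopentyl on a Weak Compound

A few compounds are considered here, and "the series" means these few. Any claim that something is new, unique, unknown or untested is made for them only; others in the source may bear on it.

In a functional assay on HepG2 cells (Homo sapiens) for antiproliferative activity, read by CCK-8 assay, with a stated time of 72 h, tested at 8 uM (on this read-out higher numbers stand for a stronger effect at the one concentration tested and lower numbers for a weaker effect), compound 1 `CN1CCN(c2nc(Cl)nc3c2ncn3Cc2ccc(C(=O)Nc3ccccc3N)cc2)CC1` gives 75%, and compound 3 `Nc1ccccc1NC(=O)c1ccc(Cn2cnc3c(Nc4cccc(Cl)c4)nc(Cl)nc32)cc1` gives 66.7%. For the measured compounds named here, the one measured step, a number 8.3 percentage points lower from compound 1 to compound 3 (within the scatter), concerns a different place on the shared core. Compound 2 `Nc1ccccc1NC(=O)c1ccc(CNc2nc(Cl)nc3c2ncn3Cc2ccccc2)cc1` gives 5.32% in this assay, the lowest of the three numbers, with compound 3 and compound 1 both far above it, beyond the scatter. Compound 4 `Nc1ccccc1NC(=O)c1ccc(CNc2nc(Cl)nc3c2ncn3C2CCCC2)cc1` differs from compound 2 in one place: cyclopentyl in place of benzyl on an aromatic nitrogen. Going by the values given here, no measured step touches this position, so the measured compounds offer no guide to a change in either direction. The step of a number 4.7 percentage points higher from compound 2 to compound 4 (within the scatter) is therefore expected to stay within the scatter. Compound 4 is expected to give about 10%, in a range from 0% to 30%.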

Compound 4, a percentage reported as inhibition, at one concentration (the size of the read-out at that concentration, not a potency): 74.9%
Compound 4: middle estimate off by 64.9 percentage points, on the low side, and the stated range ends below it.
By their numbers in this assay, from the lowest: compound 2; then compounds 3, 4 and 1 (each within the scatter of the next).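

This position is far from silent: with the rest of the structure unchanged, cyclopentyl in place of benzyl on the aromatic nitrogen gives a number 69.6 percentage points higher from compound 2 to compound 4 (beyond the scatter) in this assay. For the compounds shown here, no earlier step touched this place, so this is the first sign that the group here can separate a weak effect from a strong one at the single concentration tested. Nothing available explains why the change has so large an effect. On these data alone, whether cyclopropyl, cyclohexyl or a plain ethyl chain would serve equally well on this nitrogen remains open. So does whether the same swap would act alike with other groups elsewhere on the shared core.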